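The compounds below may be only part of what the source reports. "The series", "measured", "known", "first", "only" and "open" are said of these compounds alone.

Measured compounds in a physicochemical assay for solubility; a lower number here means a less soluble compound, a higher number a more soluble compound:

Compound 1, `COc1ccc(CC[C@@H](OC(=O)[C@@H]2CCCCN2C(=O)c2cccc3ccccc23)c2cccc(OCC(=O)O)c2)cc1OC` — compound 1 reaches only the limit > 10000 nM.
Compound 2, `COc1ccc(CC[C@@H](OC(=O)[C@@H]2CCCCN2C(=O)c2ccnc3ccccc23)c2cccc(OCC(=O)O)c2)cc1OC` — compound 2 likewise gives only the limit > 10000 nM.
Compound 3, `COc1ccc(CC[C@@H](OC(=O)[C@@H]2CCCCN2C(=O)c2nccc3ccccc23)c2cccc(OCC(=O)O)c2)cc1OC` — compound 3 again returns only the limit > 10000 nM.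

Compound 3 therefore stands where the whole series stands: at the limit of the assay, with no number beyond it, as the limit of > 10000 nM in this assay, at which 3 of the 3 values shown sit, records for every value shown. The step that the two limits leave unreadable from compound 1 to compound 3 and the step that the two limits leave unreadable from compound 2 to compound 3 are both unreadable for the same reason, as is the step that the two limits leave unreadable from compound 1 to compound 2; none of them gives a size, so none tells whether moving the nitrogen around the bicyclic group matters for solubility here.

The next compound, compound 4, `COc1ccc(CC[C@@H](OC(=O)[C@@H]2CCCCN2C(=O)c2cccc3cccnc23)c2cccc(OCC(=O)O)c2)cc1OC`, keeps every atom of compound 3 and rearranges only the aromatic group on the carbonyl carbon: quinolin-8-yl in place of isoquinolin-1-yl on a carbonyl carbon.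

Going by the values given here, no measured step bears a readable size on this change, so no step beyond the scatter can be expected from the data at hand; the expectation is simply that compound 4, like compound 3, sits at or beyond the limit. The estimated step that the limit leaves unreadable from compound 3 to compound 4 is thus expected to be nil within the scatter. For compound 4 the expected solubility in this assay is 15000 nM, with a range from 7000 nM to 40000 nM, most probably reported again as a limit.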

Compound 4, solubility: > 10000 nM
Compound 4 was reported as a limit (the forecaster's own chance of this, stated with the estimate: 85%); the middle value is on the limit's open side.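

In this assay compound 4 gives > 10000 nM, which is a limit of the assay. No step to compound 4 from compound 1, compound 2 or compound 3 can be read: the limit of > 10000 nM in this assay, at which 4 of the 4 values shown sit.

The compounds shown leave open whether naphthalen-1-yl, quinolin-4-yl, isoquinolin-1-yl and quinolin-8-yl on the carbonyl carbon differ at all in this assay.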